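Compound 3 to compound 4: trifluoromethyl in place of fluoro

This account rests on a few compounds, and the source may have more. Where it says the series, first, only, none or still open, it means among the compounds named here.

In an ADME assay on MT4 cells (Homo sapiens) for cytotoxicity, read by MTT assay, with a stated time of 4 days (on this read-out lower numbers stand for higher toxicity in this test and higher numbers for lower toxicity in this test), compound 3 `COc1c(-c2ccc(F)cc2)oc2ccc(NC(C)=O)cc2c1=O` gives 317000 nM and sits within the scatter of compound 2 `COc1ccc(-c2oc3ccc(NC(C)=O)cc3c(=O)c2OC)cc1` at 369000 nM in the same test. Compound 1 `CC(=O)Nc1ccc2oc(-c3ccc(C(F)(F)F)cc3)c(O)c(=O)c2c1` gives 7300 nM and stands lower than both, beyond the scatter from compound 3. The next change leads to compound 4 `COc1c(-c2ccc(C(F)(F)F)cc2)oc2ccc(NC(C)=O)cc2c1=O` and puts trifluoromethyl in place of fluoro on an aromatic carbon para to a large group. Going by the values given here, one measured step bears on this directly: fluoro in place of methoxy on an aromatic carbon gave a 1.2-fold lower number from compound 2 to compound 3 (0.07 log units; within the scatter) and stayed within the scatter. That is a single step with a different group leaving, so it is only modest support. Among the compounds with values here, the lower end of the range is kept wide because compound 1 sits at 7300 nM with no measured step linking it to this change. The step expected is a 1.4-fold lower number from compound 3 to compound 4 (0.16 log units; within the scatter) with no clear shift beyond the scatter. For compound 4 the estimated value is 220000 nM with an expected range from 80000 nM to 420000 nM in this assay overall.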

Compound 4, half-maximal cytotoxic concentration: 332000 nM
Estimate against measurement, compound 4: 1.5-fold (0.18 log units) below; measured number inside the range.
By their numbers in this assay, from the lowest: compound 1; then compounds 3, 4 and 2 (each within the scatter of the next).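

In this assay the aromatic carbon para to a large group now carries three groups with no separation beyond the scatter: trifluoromethyl in place of fluoro gives a 1.0-fold higher number from compound 3 to compound 4 (0.02 log units; within the scatter) and trifluoromethyl in place of methoxy gives a 1.1-fold lower number from compound 2 to compound 4 (0.05 log units; within the scatter) on the same position. With trifluoromethyl held constant, methyl in place of hydrogen on an oxygen on an aromatic ring gives a 45-fold higher number from compound 1 to compound 4 (1.66 log units; beyond the scatter) and is the large step in this set, so the low number of compound 1 does not follow from trifluoromethyl alone. Nothing measured here accounts for either outcome.

From the compounds shown here alone, whether an amine or a carboxylic acid on this aromatic carbon would stay within the scatter remains open. Also open, going by these compounds, is whether the hydrogen on that oxygen gives a similarly large step alongside fluoro or methoxy.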